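A few compounds are considered here, and "the series" means these few. Any claim that something is new, unique, unknown or untested is made for them only; others in the source may bear on it.

Measured in a functional assay on A549 cells (Homo sapiens) for cytotoxicity, read by MTT assay, with a stated time of 72 h; on this read-out lower numbers stand for stronger inhibition and higher numbers for weaker inhibition:
- compound 1 `O=C(CN1CCN(c2nnc(Cc3ccncc3)c3ccccc23)CC1)Nc1cccc(F)c1` gives 4600 nM
- compound 2 `Cc1cccc(Cl)c1NC(=O)CN1CCN(c2nnc(Cc3ccccc3)c3ccccc23)CC1` gives 7420 nM
- compound 3 `O=C(CN1CCN(c2nnc(Cc3ccccc3)c3ccccc23)CC1)Nc1cccc(F)c1` gives 130000 nM

Compound 1 and compound 2 lie within the usual scatter of each other at the low end of these three numbers, while compound 3 stands well apart. The next compound, compound 4 `O=C(CN1CCN(c2nnc(Cc3ccncc3)c3ccccc23)CC1)Nc1ccc(F)c(F)c1`, differs from compound 1 by one change: fluoro in place of hydrogen on an aromatic carbon. This turns 3-fluorophenyl into 3,4-difluorophenyl.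

For the measured compounds named here, no measured step adds a fluoro group, so the evidence is indirect. The closest step is an 18-fold higher number from compound 2 to compound 3 (1.24 log units; beyond the scatter), which swaps the ring on the amide-type nitrogen, the same ring that changes here. The step of a 28-fold higher number from compound 1 to compound 3 (1.45 log units; beyond the scatter) shows that the far end of the molecule matters too. Both are large, so this series can respond sharply, but the new change is far smaller than either and neither step gives it a direction.

The expected result in this assay is a 1.0-fold lower number from compound 1 to compound 4 (0.01 log units; within the scatter), with no shift beyond the scatter anticipated. For compound 4 the estimated value is 4500 nM, with an expected range of 1300 nM to 16000 nM.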

Compound 4, half-maximal inhibitory concentration: 3790 nM
Compound 4: the middle estimate sits 1.2-fold (0.07 log units) above what was measured; the range from low to high includes it.
By their numbers in this assay, from the lowest: compounds 4, 1 and 2 (each within the scatter of the next); then compound 3.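

In this assay, adding a fluoro group to the 3-fluorophenyl ring, ortho to a fluoro group and para to a large group, gives a 1.2-fold lower number from compound 1 to compound 4 (0.08 log units; within the scatter) and so no shift that can be told from the scatter. For the compounds shown here, this is the first direct look at this position: the ring on the amide-type nitrogen can respond sharply when it is swapped as a whole, yet this single replacement of hydrogen by fluoro, in a compound carrying pyridin-4-yl, leaves no readable mark. No measurement of any other property bears on this result.

As far as these compounds go, whether the same fluoro group would behave alike on compound 3, which carries phenyl in place of pyridin-4-yl, remains open. So does whether this position would tolerate something larger or different from fluoro, such as a methoxy group or an amine.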